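Amide aryl exchange on a shared core: outlook for compound 3

A few compounds are considered here, and "the series" means these few. Any claim that something is new, unique, unknown or untested is made for them only; others in the source may bear on it.

Values in a functional assay on NCI-H1975 cells (Homo sapiens) for inhibition, read by MTT assay, with a stated time of 72 h (a lower number here means a stronger inhibitor, a higher number a weaker inhibitor), so far:
compound 1 `O=C(CSc1nc(Nc2ccccc2)c2ccccc2n1)Nc1ccc([N+](=O)[O-])cc1`: 13000 nM
compound 2 `O=C(CSc1nc(Nc2ccccc2)c2ccccc2n1)Nc1ccc(C(F)(F)F)cc1`: 11700 nM

Compound 2 stands alongside compound 1 on these two numbers: the step of a 1.1-fold lower number from compound 1 to compound 2 (0.05 log units; within the scatter) lies within the scatter, so the two values give no order between them. Compound 3 `O=C(CSc1nc(Nc2ccccc2)c2ccccc2n1)Nc1ccc(F)c(Cl)c1` differs from compound 2 by 3-chloro-4-fluorophenyl in place of 4-(trifluoromethyl)phenyl on an amide-type nitrogen. Among the measured compounds shown here, no measured step covers this exact exchange. For the measured compounds named here, the one step at hand, a 1.1-fold lower number from compound 1 to compound 2 (0.05 log units; within the scatter), replaced one group on the same aryl ring of the amide nitrogen and moved the number by no more than the scatter, so a further swap of groups on that ring is expected to give little movement here. The expectation for this assay is therefore a step of a 1.1-fold lower number from compound 2 to compound 3 (0.03 log units; within the scatter), with no change beyond the scatter. Compound 3 is estimated at 11000 nM, with a range from 4000 nM to 30000 nM.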

Compound 3, half-maximal inhibitory concentration: 9390 nM
Compound 3: the middle estimate sits 1.2-fold (0.07 log units) above what was measured; the range from low to high includes it.
By their numbers in this assay, from the lowest: compounds 3, 2 and 1 (each within the scatter of the next).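

In this assay, the exchange on the amide-type nitrogen now extends to a ring carrying two halogens, and 3-chloro-4-fluorophenyl gives a 1.2-fold lower number from compound 2 to compound 3 (0.10 log units; within the scatter). Set against the nitro-bearing ring, the same group gives a 1.4-fold lower number from compound 1 to compound 3 (0.14 log units; within the scatter), so all three aryl groups on this nitrogen stand level, and none of these exchanges separates from the others. No measurement is available that would account for this flat response.

Going by these compounds, it remains open whether a carboxylic acid or an amine on this aryl ring would move the number beyond the scatter. The compounds shown also leave open whether a change away from this ring, such as a longer chain between the sulfur and the carbonyl, would do so.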